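The source may report more compounds than this note shows. Statements on the series, on what has been measured and on what is new or still open speak of the compounds shown alone.

Measured in a functional assay on HEL cells (Homo sapiens) for cytotoxicity, read by microscopy; a lower number here means a stronger inhibitor, a higher number a weaker inhibitor:
- Compound 1 `O=C1O/C(=C\Cn2cc(C(F)(F)F)c(=O)[nH]c2=O)C(OCc2ccccc2)=C1OCc1ccccc1`: 2000 nM
- Compound 2 `O=C1O/C(=C\Cn2ccc(=O)[nH]c2=O)C(OCc2ccccc2)=C1OCc1ccccc1`: 20000 nM
- Compound 3 `O=C1O/C(=C\Cn2cc(Cl)c(=O)[nH]c2=O)C(OCc2ccccc2)=C1OCc1ccccc1`: 5000 nM

Compound 3 holds the second highest of the three numbers, with compound 1 lower and compound 2 higher. Compound 4 `O=C1O/C(=C\Cn2cc(Br)c(=O)[nH]c2=O)C(OCc2ccccc2)=C1OCc1ccccc1` differs from compound 3 by one change, bromo in place of chloro on an aromatic carbon. Two measured steps at that same carbon bear on it, a 4.0-fold lower number from compound 2 to compound 3 (0.60 log units; beyond the scatter) and a 2.5-fold higher number from compound 1 to compound 3 (0.40 log units; beyond the scatter). Both are modest, so only a small step is expected in this assay, if anything towards a lower number. The expected step is a 1.3-fold lower number from compound 3 to compound 4 (0.10 log units; within the scatter). Compound 4 is estimated at 4000 nM, with an expected range of 1500 nM to 10000 nM.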

Compound 4, half-maximal inhibitory concentration: 5000 nM
Estimate against measurement, compound 4: 1.3-fold (0.10 log units) below, and the stated range covers the measured number.
By their numbers in this assay, from the lowest: compound 1; then compounds 3 and 4 (each within the scatter of the next); then compound 2.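

In this assay, swapping chloro for bromo at this carbon makes no difference that can be read (no change at the digits printed from compound 3 to compound 4 (within the scatter)). Bromo keeps the gain over hydrogen that chloro showed (a 4.0-fold lower number from compound 2 to compound 4 (0.60 log units; beyond the scatter)), and like chloro it leaves a gap to trifluoromethyl (a 2.5-fold higher number from compound 1 to compound 4 (0.40 log units; beyond the scatter)). Nothing measured here explains these steps.

As far as these compounds go, whether iodo, fluoro, methyl or a nitrile at this carbon would fall with the two halogens or with trifluoromethyl remains open. Also open, from the compounds shown here alone, is how an amine or a carboxylic acid at this carbon would compare.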